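Chloro for hydrogen on the distal phenoxy ring

The source may report more compounds than this note shows. Statements on the series, on what has been measured and on what is new or still open speak of the compounds shown alone.

Two compounds of the series carry a measurement in a physicochemical assay for lipophilicity, in phosphate buffer, measured as octanol-water partition; a lower number here means a more polar compound, a higher number a more lipophilic compound. Compound 1, `O=c1c2ccccc2nc(-c2ccccc2)n1/N=C/c1ccc(Oc2ccc([N+](=O)[O-])cc2)cc1`, gives 6.12. Compound 2, `O=c1c2ccccc2nc(-c2ccccc2)n1/N=C/c1ccc(Oc2ccccc2)cc1`, gives 6.13. The only measured step, a number 0.01 log units higher from compound 1 to compound 2 (within the scatter), leaves the two numbers within the scatter of each other, so compound 2 and compound 1 stand at the same level on the numbers shown.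

Compound 3, `O=c1c2ccccc2nc(-c2ccccc2)n1/N=C/c1ccc(Oc2ccc(Cl)cc2)cc1`, differs from compound 2 as follows: chloro in place of hydrogen on an aromatic carbon.

Among the compounds with values here, no measured step covers a chloro entering in place of a hydrogen; the one step available, from nitro to hydrogen, was flat, and says nothing direct about this change. The expectation therefore rests on the structural change alone: a single chlorine atom entering an aromatic ring, with no donors or acceptors added, is expected to move the partition coefficient upward by a step beyond the scatter, estimated as a number 0.47 log units higher from compound 2 to compound 3 (beyond the scatter). On that basis compound 3 is estimated at 6.6 in this assay, with a range from 6.1 to 7.1.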

Compound 3, partition coefficient: 6.38
Beside the measured number, compound 3's estimate is 0.22 log units above it, within the range that was stated.
By their numbers in this assay, from the lowest: compounds 1, 2 and 3 (each within the scatter of the next).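

At the aromatic carbon para to a large group, this assay now covers three different groups: chloro in place of hydrogen gives a number 0.25 log units higher from compound 2 to compound 3 (within the scatter) and chloro in place of nitro gives a number 0.26 log units higher from compound 1 to compound 3 (within the scatter) on the same carbon. The earlier pair tied only hydrogen and nitro to one level, whereas hydrogen, nitro and chloro now all read at that level, so none of compounds 1, 2 and 3 can be set apart from the others on these numbers. No evidence is at hand that bears on why the three readings sit together.

The compounds shown leave open whether this level would hold for an amine or a carboxylic acid on the same carbon, or for a longer chain such as butoxy there, any of which would test the position with a group quite unlike hydrogen, nitro and chloro. They also leave open whether chloro in place of hydrogen would read the same on another ring of the shared core, since all three compounds vary at this one carbon only.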